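Loss of the ethyl in compound 3: expected effect

The compounds below may be only part of what the source reports. "The series", "measured", "known", "first", "only" and "open" are said of these compounds alone.

Working notes. Within the data shown here, compound 3 `CCc1ccccc1C(=O)Nc1c[nH]nc1C(=O)N[C@H]1CC[C@H](OC)CC1` gives 3400 nM in an ADME assay on MRC5 cells (Homo sapiens) for inhibition, with a stated time of 72 h (a higher number here means that more compound is needed for the effect, a lower number that less compound is needed), the lowest of the three numbers so far. Compound 1 `CO[C@H]1CC[C@H](NC(=O)c2n[nH]cc2NC(=O)c2cnc3ccccn23)CC1` gives 5900 nM and lies within the scatter of compound 3, while compound 2 `CO[C@H]1CC[C@H](NC(=O)c2n[nH]cc2NC(=O)c2ccc(N3CCN(C)CC3)cc2)CC1` gives 20000 nM, beyond the scatter. Compound 4 `CO[C@H]1CC[C@H](NC(=O)c2n[nH]cc2NC(=O)c2ccccc2)CC1` differs from compound 3 by hydrogen in place of ethyl on an aromatic carbon. Among the measured compounds shown here, no measured step touches this part of the structure. For the measured compounds named here, the only step, a 1.7-fold lower number from compound 1 to compound 3 (0.24 log units; within the scatter), swapped the whole acyl group and still stayed within the scatter, so the series gives little guidance for a smaller change. For compound 4 the expected step is a 1.5-fold higher number from compound 3 to compound 4 (0.17 log units; within the scatter), nothing beyond the scatter, leaning slightly toward a higher number. Compound 4 is therefore estimated at 5000 nM, within a range from 2000 nM to 15000 nM.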

Compound 4, half-maximal effective concentration: 800 nM
Compound 4: middle estimate off by 6.3-fold (0.80 log units), on the high side; the measured number lies below the stated range.
By their numbers in this assay, from the lowest: compound 4; then compounds 3 and 1 (each within the scatter of the next); then compound 2.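

In this assay, among these compounds, the ethyl does count at this place: hydrogen in its place on the aromatic carbon gives a 4.3-fold lower number from compound 3 to compound 4 (0.63 log units; beyond the scatter), the first measured step at this position. Unlike the 2-ethylphenyl of compound 3, the plain phenyl separates clearly from both other acyl groups, with a 7.4-fold lower number from compound 1 to compound 4 (0.87 log units; beyond the scatter) and a 25-fold lower number from compound 2 to compound 4 (1.40 log units; beyond the scatter) as the steps. No measured evidence bears on why the number falls. Still open, as far as these compounds go, is whether a methyl, a methoxy or an amine on the same aromatic carbon keeps the lower number or moves back toward that of compound 3.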